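A Third Fluoro-Nitro Arrangement, Not Yet Measured

The source may report more compounds than this note shows. Statements on the series, on what has been measured and on what is new or still open speak of the compounds shown alone.

- Compound 1 `O=C(O)c1ccc(C(=O)/C(=C\c2ccc([N+](=O)[O-])cc2F)SCc2ccc(Br)cc2)cc1`: < 1000 ug/mL
- Compound 2 `O=C(O)c1ccc(C(=O)/C(=C\c2ccc(F)cc2[N+](=O)[O-])SCc2ccc(Br)cc2)cc1`: < 1000 ug/mL

In a physicochemical assay for solubility (a higher number here means a more soluble compound, a lower number a less soluble compound), compound 2 gives < 1000 ug/mL, which is a limit of the assay and not a number. Compound 1 gives < 1000 ug/mL, and this too is a limit. So the evidence so far is the limit of < 1000 ug/mL in this assay, at which 2 of the 2 values shown sit, and compound 2 has no exact position on the scale.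

The next compound, compound 3 `O=C(O)c1ccc(C(=O)/C(=C\c2ccc([N+](=O)[O-])c(F)c2)SCc2ccc(Br)cc2)cc1`, has the same atoms as compound 2, joined differently: 3-fluoro-4-nitrophenyl in place of 4-fluoro-2-nitrophenyl on a double-bonded chain carbon bound to a double-bonded chain carbon.

Among the measured compounds shown here, the one measured step that bears on this exchange is a step that the two limits leave unreadable from compound 1 to compound 2. Its size cannot be read, so it offers neither a size nor a direction to carry over, and no change beyond the usual scatter is expected. The expected step is a step that the limit leaves unreadable from compound 2 to compound 3. The estimate for compound 3 is 200 ug/mL, with an expected range from 20 ug/mL to 1000 ug/mL.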

Compound 3, solubility: < 1000 ug/mL
Compound 3: a limit, no number; the forecaster's own chance of this, stated with the estimate: 85%; the middle value lies beyond the limit too.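

Among the compounds shown here, compound 1, compound 2 and compound 3 each give a limit and not a number in this assay, so no step among them can be read: the limit of < 1000 ug/mL in this assay, at which 3 of the 3 values shown sit.

Where each compound truly stands, and whether the 2-fluoro-4-nitrophenyl, 4-fluoro-2-nitrophenyl and 3-fluoro-4-nitrophenyl versions differ at all, stays open.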